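Hydroxy-to-fluoro change on the anilide of compound 3

The source may report more compounds than this note shows. Statements on the series, on what has been measured and on what is new or still open speak of the compounds shown alone.

Going by the values given here, compound 3 `CN(C)C(=O)c1cc2cnc(Nc3ccc(NC(=O)C4(C(=O)Nc5ccc(O)cc5)CC4)cc3)nc2n1C1CCCC1` stands highest of the three numbers so far in a functional assay on NCI-H460 cells (Homo sapiens) for inhibition, read by CCK-8 assay, with a stated time of 72 h, tested at 1 uM (a lower number here means less inhibition of growth, a higher number more inhibition of growth at the concentration tested), where compound 3 gives 90.4%. The next nearest is compound 1 `CN(C)C(=O)c1cc2cnc(Nc3ccc(NC(=O)C4(C(=O)Nc5ccc(F)cc5)CC4)cc3F)nc2n1C1CCCC1`, which in this assay gives 11.9%, and the furthest is compound 2 `CN(C)C(=O)c1cc2cnc(Nc3ccc(NC(=O)C4(C(=O)Nc5ccc(Cl)c(C(F)(F)F)c5)CC4)cc3)nc2n1C1CCCC1`, which gives 2.1%. The one step measured within a single change, a number 88.3 percentage points higher from compound 2 to compound 3 (beyond the scatter), is large and sits well beyond the scatter, so the group on the amide-type nitrogen has already shown itself able to move the read-out across most of its range.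

Compound 4 `CN(C)C(=O)c1cc2cnc(Nc3ccc(NC(=O)C4(C(=O)Nc5ccc(F)cc5)CC4)cc3)nc2n1C1CCCC1` has not yet been measured. It differs from compound 3 by fluoro in place of hydroxy on an aromatic carbon. Among the compounds with values here, no measured step covers this exact exchange. Compound 1 carries the same 4-fluorophenyl amide as compound 4, but also a fluoro on the central ring, so only its low value and the high value of compound 3 can be set side by side. On those numbers, the removal of hydroxy is expected to cost most of the inhibition, and the step of a number 72.4 percentage points lower from compound 3 to compound 4 (beyond the scatter) is estimated to be large and downward. Compound 4 is therefore expected to give about 18%, within a range of 3% to 50%.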

Compound 4, percent growth inhibition at one concentration: 79.9%
Beside the measured number, compound 4's estimate is 61.9 percentage points below it; measured number above the stated range.
By their numbers in this assay, from the lowest: compounds 2 and 1 (each within the scatter of the next); then compound 4; then compound 3.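

Working notes on the anilide: in this assay, the step of a number 10.5 percentage points lower from compound 3 to compound 4 (beyond the scatter) is modest next to the other steps in the series, so most of the inhibition of growth seen with compound 3 survives when fluoro replaces hydroxy, and hydroxy is not a requirement for high inhibition at this position. The step of a number 77.8 percentage points higher from compound 2 to compound 4 (beyond the scatter) is large. Compound 4 lacks hydroxy just as compound 2 does, so the absence of hydroxy does not by itself go with a low number; the loss goes with the 4-chloro-3-(trifluoromethyl)phenyl group as a whole. The step of a number 68 percentage points higher from compound 1 to compound 4 (beyond the scatter) is also large, so the low number of compound 1 goes with its extra fluoro and not with the 4-fluorophenyl amide it shares with compound 4.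

Nothing at hand bears on why any of these steps take the size they do. Also open, going by these compounds, are whether chloro or trifluoromethyl alone accounts for the loss in compound 2, and how an amine or a methoxy group on the same aromatic carbon would compare with hydroxy and fluoro.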